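The source may hold more compounds than are shown below. What is called first, only, known or untested is meant among the compounds shown, and "the series" means these compounds.

Measured compounds:
compound 1, `O=C(CI)NCCCCC(=O)NCCCCCCNc1ncnc2c1ncn2[C@@H]1O[C@H](COP(=O)(O)OP(=O)(O)OP(=O)(O)O)[C@@H](O)[C@H]1O`, 0%
compound 2, `O=C(CI)NCCCCCC(=O)NCCCNc1ncnc2c1ncn2[C@@H]1O[C@H](COP(=O)(O)OP(=O)(O)OP(=O)(O)O)[C@@H](O)[C@H]1O`, 0%
compound 3, `O=C(CI)NCCCC(=O)NCCCCCCNc1ncnc2c1ncn2[C@@H]1O[C@H](COP(=O)(O)OP(=O)(O)OP(=O)(O)O)[C@@H](O)[C@H]1O`, 0%

In an assay on isolated protein for inhibition of hexokinase-2 (Rattus norvegicus), with a stated time of 6 h, tested at 10 mM (on this read-out lower numbers stand for less inhibition and higher numbers for more inhibition at the one concentration tested (going by the name of the read-out)), compound 1 gives 0%. Compound 2 gives 0%, and compound 3 gives 0%. All three sit level at the digits printed, within the scatter of one another. For the measured compounds named here, the one counted step among them, ((((iodomethyl)carbonyl)amino)methyl in place of ((iodomethyl)carbonyl)amino on a saturated chain carbon, three bonds along the chain from a carbonyl carbon), reads no change at the digits printed from compound 3 to compound 1 (within the scatter). Compound 2 shares no counted difference with compound 3; the difference between the two cores is not broken down here.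

Compound 4, `O=C(CI)NCCCCCCC(=O)NCCCNc1ncnc2c1ncn2[C@@H]1O[C@H](COP(=O)(O)OP(=O)(O)OP(=O)(O)O)[C@@H](O)[C@H]1O`, is not yet measured. It differs from compound 2 by (((iodomethyl)carbonyl)amino)methyl in place of ((iodomethyl)carbonyl)amino on a saturated chain carbon, five bonds along the chain from a carbonyl carbon. This is the same kind of change as that from compound 3 to compound 1, not the same change: there the place is three bonds along the chain from a carbonyl carbon, here it is five bonds along the chain from a carbonyl carbon. The step from compound 2 to compound 4 in this assay is expected to be no change at the digits printed from compound 2 to compound 4 (within the scatter) because the earlier step of this kind was no change at the digits printed from compound 3 to compound 1 (within the scatter) and compounds 1, 2 and 3 sit level with one another. Compound 4 is therefore estimated at 0%, between -8% and 10%.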

Compound 4, a percentage reported as inhibition, at one concentration (the size of the read-out at that concentration, not a potency): 0%
Compound 4: the middle estimate sits on the measured number at the digits printed; the measured number falls inside the stated range.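

In this assay, putting (((iodomethyl)carbonyl)amino)methyl in place of ((iodomethyl)carbonyl)amino gives no change at the digits printed from compound 2 to compound 4 (within the scatter). Set beside the earlier step on the other core, the change reads the same on both: the same change on two cores in this assay, no change at the digits printed (within the scatter) from compound 3 to compound 1 and no change at the digits printed (within the scatter) from compound 2 to compound 4, 0 percentage points apart, within the scatter of two such steps This does not show that the change is silent in general: compound 1, compound 2, compound 3 and compound 4 all print the same value, with compound 4 at 0%, so neither step starts from any measured inhibition, and the agreement says nothing about how the change would read on a core that shows some.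

The compounds shown leave open whether any chain length in this series gives a reading above that level in this assay. They also leave open what a longer chain such as 4-(((iodomethyl)carbonyl)amino)butyl, or a chloromethyl carbonyl or a free amine at the chain end in place of the ((iodomethyl)carbonyl)amino group, would give.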